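The source may hold more compounds than are shown below. What is called first, only, known or untested is meant among the compounds shown, and "the series" means these compounds.

Working notes on the series in an assay on lysate for inhibition of phosphatidylcholine:ceramide cholinephosphotransferase 2 (Homo sapiens), read by HPLC, with stated times of 30 min and 2 h; on this read-out lower numbers stand for stronger inhibition and higher numbers for weaker inhibition.

Among the compounds with values here, compound 2 `O=C(Nc1cccnc1)c1ccccc1OCc1cc(Cl)ccc1Cl` gives 990 nM in this assay, the lowest of the two numbers so far; the nearest is compound 1 `O=C(Nc1cccnc1)c1ccccc1OCc1ccccc1Cl` with 1100 nM, and the two lie within the scatter of each other. Within the data shown here, the only measured step, a 1.1-fold lower number from compound 1 to compound 2 (0.05 log units; within the scatter), is chloro in place of hydrogen on an aromatic carbon and stays within the scatter.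

Compound 3 `O=C(Nc1cccnc1)c1ccccc1OCc1c(Cl)cccc1Cl` is not yet measured. It differs from compound 2 by 2,6-dichlorophenyl in place of 2,5-dichlorophenyl on a saturated chain carbon bound to an oxygen on an aromatic ring; the two have the same atoms, joined differently. The step from compound 1 to compound 2 is the only one that bears on it, and it showed no change beyond the scatter, so no evidence here points to either direction. The expected step is a 1.0-fold higher number from compound 2 to compound 3 (0.00 log units; within the scatter), that is, none beyond the scatter. Compound 3 is therefore estimated at 1000 nM, with a range from 400 nM to 2500 nM.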

Compound 3, half-maximal inhibitory concentration: 690 nM
Compound 3: the middle estimate sits 1.4-fold (0.16 log units) above what was measured; low and high end bracket the measured number.
By their numbers in this assay, from the lowest: compounds 3, 2 and 1 (each within the scatter of the next).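

In this assay, rearranging the same atoms, with 2,6-dichlorophenyl in place of 2,5-dichlorophenyl on a saturated chain carbon bound to an oxygen on an aromatic ring, gives a 1.4-fold lower number from compound 2 to compound 3 (0.16 log units; within the scatter) and so stays within the scatter. Chloro in place of hydrogen on an aromatic carbon gives a 1.6-fold lower number from compound 1 to compound 3 (0.20 log units; within the scatter) and likewise stays within the scatter, so across compounds 1, 2 and 3 neither the number of chlorines nor the arrangement of the two separates from the scatter. No measurement at hand accounts for these numbers or ties them to any feature of the groups.

The compounds shown carry only chloro on this ring, so the effect of a methoxy or trifluoromethyl group there remains open, as does that of an unsubstituted phenyl. From the compounds shown here alone, whether any change at this place can move the number beyond the scatter also remains open.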